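Chain lengthening on the thioether of a chloromethyl ketone

The source may hold more compounds than are shown below. What is called first, only, known or untested is meant among the compounds shown, and "the series" means these compounds.

Compound 1 `CCCCCCSC[C@H](NC(C)=O)C(=O)CCl` carries the shortest chain of the set. In a functional assay on MOLT-3 cells (Homo sapiens) (on this read-out lower numbers stand for stronger inhibition and higher numbers for weaker inhibition), compound 1 gives 700 nM. Compound 2 `CCCCCCCSC[C@H](NC(C)=O)C(=O)CCl` differs from it by methyl in place of hydrogen on a saturated chain carbon, six bonds along the chain from a sulfur, and in this assay compound 2 gives 2500 nM, a step of a 3.6-fold higher number from compound 1 to compound 2 (0.55 log units; beyond the scatter). Compound 3 `CCCCCCCCCCCCCSC[C@H](NC(C)=O)C(=O)CCl` differs from compound 1 by heptyl in place of hydrogen on a saturated chain carbon, six bonds along the chain from a sulfur. In this assay compound 3 reaches only the limit > 100000 nM, which is a limit of the assay and not a number, as the limit of > 100000 nM in this assay, at which 1 of the 3 values shown sits, records. The steps of an at least 140-fold higher number from compound 1 to compound 3 (2.15 log units; beyond the scatter) and an at least 40-fold higher number from compound 2 to compound 3 (1.60 log units; beyond the scatter) are both large.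

Compound 4 `CCCCCCCCCCCCCCSC[C@H](NC(C)=O)C(=O)CCl` is not yet measured in this assay. It differs from compound 3 by methyl in place of hydrogen on a saturated chain carbon, ten or more bonds along the chain from a sulfur. Within the data shown here, this is the same kind of change as the one from compound 1 to compound 2, but the place along the chain differs, as the two differences just given state. Beside the earlier step of a 3.6-fold higher number from compound 1 to compound 2 (0.55 log units; beyond the scatter), compound 4 is expected to show a step that the limit leaves unreadable from compound 3 to compound 4. That expectation rests on compound 3 already sitting at the limit > 100000 nM and on every lengthening so far raising the number. For compound 4 in this assay the estimate is 200000 nM, between 60000 nM and 800000 nM, with a limit reading the most likely outcome.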

Compound 4, half-maximal inhibitory concentration: 8800 nM
For compound 4 the middle estimate is 23-fold (1.36 log units) above the measured one; the whole stated range lies above it.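

Methyl in place of hydrogen on a saturated chain carbon does not carry from one core to another in this assay, and the step of an at least 11-fold lower number from compound 3 to compound 4 (1.05 log units; beyond the scatter) runs against the direction of the earlier one: the same change on two cores in this assay, a 3.6-fold higher number (0.55 log units; beyond the scatter) from compound 1 to compound 2 and an at least 11-fold lower number (1.05 log units; beyond the scatter) from compound 3 to compound 4, at least 40-fold (1.60 log units) apart, beyond the scatter of two such steps

The value of compound 3, > 100000 nM, is a limit of the assay and not a number: the limit of > 100000 nM in this assay, at which 1 of the 4 values shown sits.

The longer chain still gives a higher number against the two shortest chains, with a 3.5-fold higher number from compound 2 to compound 4 (0.55 log units; beyond the scatter) and a 13-fold higher number from compound 1 to compound 4 (1.10 log units; beyond the scatter), but a rise with every added carbon does not hold, compound 4 going against it, and these values give no reason for the reversal.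

Open, on these data alone, are the chain lengths between those of compound 2 and compound 3, and whether a longer chain than that of compound 4 keeps its lower number. Also open, as far as these compounds go, is whether a chain ending in an amine or a carboxylic acid follows the same course.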